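Methoxy for fluoro on the core of compound 1

The source may hold more compounds than are shown below. What is called first, only, known or untested is meant among the compounds shown, and "the series" means these compounds.

Compound 1 `Cc1ccc(S(=O)(=O)c2cnc3ccc(F)cc3c2N2CCC(C)CC2)cc1` gives 91% in an assay on isolated protein for displacement of a labelled ligand from metabotropic glutamate receptor 5 (Homo sapiens), with a stated time of 60 min, tested at 1 uM; on this read-out lower numbers stand for less inhibition and higher numbers for more inhibition at the one concentration tested (going by the name of the read-out). Among the three measured compounds it stands second highest; its nearest is compound 3 `Cc1ccc(S(=O)(=O)c2cnc3ccc(F)cc3c2N2CCC(C)CC2)cc1C` with 92%, its furthest compound 2 `COc1ccc(S(=O)(=O)c2cnc3ccc(F)cc3c2N2CCC(C)CC2)cc1` with 85%, and the steps of a number 1 percentage points higher from compound 1 to compound 3 (within the scatter) and a number 6 percentage points lower from compound 1 to compound 2 (within the scatter) both stay within the scatter, as does a number 7 percentage points higher from compound 2 to compound 3 (within the scatter).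

Compound 4 `COc1ccc2ncc(S(=O)(=O)c3ccc(C)cc3)c(N3CCC(C)CC3)c2c1` differs from compound 1 in this way: methoxy in place of fluoro on an aromatic carbon. All measured steps concern the sulfonyl aryl group, not the fused core, so none bears directly on this change; the nearest in kind is a number 6 percentage points lower from compound 1 to compound 2 (within the scatter), where methoxy also enters. No step beyond the scatter is therefore expected for a number 6 percentage points lower from compound 1 to compound 4 (within the scatter). For compound 4 a value of 85% is estimated, in the range 68% to 95%.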

Compound 4, a percentage reported as inhibition, at one concentration (the size of the read-out at that concentration, not a potency): 90%
Compound 4: middle estimate off by 5 percentage points, on the low side, and the stated range covers the measured number.
By their numbers in this assay, from the lowest: compounds 2, 4, 1 and 3 (each within the scatter of the next).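

Going by these compounds alone, the earlier compounds varied only the sulfonyl aryl group, so the step of a number 1 percentage points lower from compound 1 to compound 4 (within the scatter) is the first reading on the shared core. At this aromatic carbon, methoxy in place of fluoro leaves the number within the scatter, so the position accepts either group at the one concentration tested. Nothing available explains this result.

As far as these compounds go, whether an amine, a carboxylic acid or a longer chain such as butoxy would be accepted at this carbon stays open. Also open, from the compounds shown here alone, is how methoxy on the core pairs with other sulfonyl aryl groups, such as 3,4-dimethylphenyl.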